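Swapping Trifluoromethyl for Nitro on a Benzothiazole Amide

The source may hold more compounds than are shown below. What is called first, only, known or untested is meant among the compounds shown, and "the series" means these compounds.

Of the compounds shown here, three have been tested so far in a functional assay on MDA-MB-231 cells (Homo sapiens) for inhibition; a higher number here means a weaker inhibitor of growth, a lower number a stronger inhibitor of growth. Compound 1 `O=C(CN1CCN(c2ccccc2F)CC1)Nc1ccc(-c2nc3ccccc3s2)cc1` gives 200 nM in this assay. Compound 2 `Cc1cc(C)c2sc(NC(=O)c3ccc(C(F)(F)F)cc3)nc2c1` gives 290 nM in this assay. Compound 3 `Clc1cccc(-n2cc(CNc3ccc(-c4nc5ccccc5s4)cc3)nn2)c1` gives 200 nM in this assay. Among the measured compounds shown here, the three values sit close together: the value of compound 2 lies within the usual scatter of both compound 1 and compound 3, so the numbers do not separate any of them from the others, and no compound can be called stronger or weaker than the rest.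

Compound 4 `Cc1cc(C)c2sc(NC(=O)c3ccc([N+](=O)[O-])cc3)nc2c1` has not yet been measured. It differs from compound 2 in one place: nitro in place of trifluoromethyl on an aromatic carbon. For the measured compounds named here, the two groups are of similar size and both carry no charge, and no pair of measured compounds shows how such a swap plays out in this assay.

Going by the values given here, with nothing among the measured compounds pointing one way, the expectation is a step no larger than the scatter, and the expected move from compound 2 to compound 4 is a 1.2-fold higher number from compound 2 to compound 4 (0.08 log units; within the scatter). For compound 4 the estimate in this assay is 350 nM, with a range from 120 nM to 1000 nM.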

Compound 4, concentration for 50% growth inhibition: 290 nM
Estimate against measurement, compound 4: 1.2-fold (0.08 log units) above; measured number inside the range.
By their numbers in this assay, from the lowest: compounds 1, 3, 2 and 4 (each within the scatter of the next).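

In this assay, among the compounds shown here, nitro in place of trifluoromethyl on the aromatic carbon para to a large group brings no change at the digits printed from compound 2 to compound 4 (within the scatter), and this is the first pair of compounds here that differ in one place. It gives this position its first direct reading: the two groups differ in their counts of heavy atoms and hydrogen-bond acceptors, yet the growth-inhibition numbers of the two compounds cannot be told apart. No measurement of any property of either group comes with this result, so the data offer no explanation for the absence of a step.

A single pair cannot show how much freedom this position allows, and an amine, a carboxylic acid or a plain hydrogen on the same aromatic carbon could give a very different number from the two groups compared here. From the compounds shown here alone, what a longer chain such as ethyl would do in place of a methyl group on the shared core is equally open, as is whether the same swap would give a similar result on a different core.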